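Swapping one five-membered ring for another

The source may hold more compounds than are shown below. What is called first, only, known or untested is meant among the compounds shown, and "the series" means these compounds.

Measured so far in an ADME assay on MT4 cells (Homo sapiens) for cytotoxicity; on this read-out lower numbers stand for higher toxicity in this test and higher numbers for lower toxicity in this test:
- compound 1 (`COC(=O)N[C@H](C(=O)NN(CCC[C@@](O)(Cc1ccccc1)C(=O)N[C@H]1c2ccccc2C[C@H]1O)Cc1ccc(-c2cncnc2)cc1)C(C)(C)C`): > 10000 nM (a limit)
- compound 2 (`COC(=O)N[C@H](C(=O)NN(CCC[C@@](O)(Cc1ccccc1)C(=O)N[C@H]1c2ccccc2C[C@H]1O)Cc1ccc(-c2noc(C)n2)cc1)C(C)(C)C`): > 10000 nM (a limit)

Compound 2 gives only a limit, > 10000 nM, and no exact number. Both compounds stop there (the limit of > 10000 nM in this assay, at which 2 of the 2 values shown sit). Compound 3 (`COC(=O)N[C@H](C(=O)NN(CCC[C@@](O)(Cc1ccccc1)C(=O)N[C@H]1c2ccccc2C[C@H]1O)Cc1ccc(-c2nccs2)cc1)C(C)(C)C`) carries 1,3-thiazol-2-yl in place of 5-methyl-1,2,4-oxadiazol-3-yl on an aromatic carbon. Within the data shown here, the one measured swap at this place is a step that the two limits leave unreadable from compound 1 to compound 2, so it offers no size to carry over. No change beyond the scatter is therefore expected in this assay, and no direction can be given. The expected step is a step that the limit leaves unreadable from compound 2 to compound 3 in size. Compound 3 is estimated at 12000 nM, with an expected range of 5000 nM to 30000 nM. Another limit would be no surprise.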

Compound 3, half-maximal cytotoxic concentration: > 10000 nM
Compound 3: no number, only a limit; the forecaster's own chance of this, stated with the estimate: 75%; the middle value lies beyond the limit too.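

In this assay, among these compounds, compound 3 gives only a limit, > 10000 nM, so no step between compound 1, compound 2 and compound 3 can be read: the limit of > 10000 nM in this assay, at which 3 of the 3 values shown sit. From the compounds shown here alone, whether swapping the ring at this place changes the read-out at all stays open, with no exact number for any of the three compounds.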